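Notes on the sulfonyl substituent in the acylsulfonamide series

The source may report more compounds than this note shows. Statements on the series, on what has been measured and on what is new or still open speak of the compounds shown alone.

Measured so far in an assay on cells for displacement of a labelled ligand from prostaglandin E2 receptor EP4 subtype (Homo sapiens), read by scintillation counting; on this read-out higher numbers stand for weaker inhibition and lower numbers for stronger inhibition:
- compound 1 `COc1ccc(-c2ccc(OCc3cc(C(=O)NS(=O)(=O)c4cccs4)oc3C)cc2)cc1`: 3.6 nM
- compound 2 `CCCS(=O)(=O)NC(=O)c1cc(COc2ccc(-c3ccc(OC)cc3)cc2)c(C)o1`: 5 nM

Among the compounds with values here, compound 2 holds the higher of the two numbers in this assay, and its only neighbour is compound 1, separated by the step of a 1.4-fold higher number from compound 1 to compound 2 (0.14 log units; within the scatter). The two values therefore sit within the scatter of each other, and no order between them can be read.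

Compound 3 `COc1ccc(-c2ccc(OCc3cc(C(=O)NS(=O)(=O)c4ccc(C)cn4)oc3C)cc2)cc1` is not yet measured. It differs from compound 2 in one place: 5-methylpyridin-2-yl in place of propyl on a sulfonyl sulfur. Within the data shown here, the single step that bears on this exchange is a 1.4-fold higher number from compound 1 to compound 2 (0.14 log units; within the scatter), where an aromatic ring on the same sulfonyl sulfur was replaced by propyl and the number barely moved. Going the other way, from propyl to a six-membered aromatic ring with one hetero atom, the expectation is a step of about a 1.4-fold lower number from compound 2 to compound 3 (0.15 log units; within the scatter) in this assay, that is, nothing beyond the scatter, perhaps leaning toward a slightly lower number.

Compound 3 is therefore estimated at 3.5 nM, with a range of 1.5 nM to 9 nM in this assay.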

Compound 3, inhibition constant: 15 nM
Estimate against measurement, compound 3: 4.3-fold (0.63 log units) below; the measured number lies above the stated range.
By their numbers in this assay, from the lowest: compounds 1 and 2 (each within the scatter of the next); then compound 3.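

In this assay, within the data shown here, the group on the sulfonyl sulfur proves not to be freely exchangeable: 5-methylpyridin-2-yl gives a 3.0-fold higher number from compound 2 to compound 3 (0.48 log units; beyond the scatter) against propyl and a 4.2-fold higher number from compound 1 to compound 3 (0.62 log units; beyond the scatter) against thiophen-2-yl, both modest, and these are the first steps at this place to lie beyond the scatter. Aromatic ring against open chain does not sort the three compounds: compound 1 carries an aromatic ring and compound 2 a propyl chain, yet those two stay within the scatter of each other, and only the six-membered ring of compound 3 with its methyl and its ring nitrogen stands apart. Nothing at hand gives a measured reason for the higher number of compound 3.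

The compounds shown do not separate the ring nitrogen from the methyl in 5-methylpyridin-2-yl, since both enter together; plain pyridin-2-yl, phenyl or 5-methylthiophen-2-yl on the same sulfonyl sulfur would divide the step between them. As far as these compounds go, how far the tolerance for propyl extends is also open, with a longer chain such as butyl or a branched one such as isopropyl as the direct tests.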